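The source may report more compounds than this note shows. Statements on the series, on what has been measured and on what is new or still open speak of the compounds shown alone.

Compound 2 `CC1=NN(c2ccc(Br)cc2)C(=O)C12C=CC(=O)C=C2c1ccccc1` is one of three compounds for which antiproliferative activity has been measured. In a functional assay on A549 cells (Homo sapiens) for antiproliferative activity, read by CCK-8 assay, with a stated time of 72 h (on this read-out lower numbers stand for stronger inhibition and higher numbers for weaker inhibition), compound 2 gives only a limit of the assay, > 100000 nM. Compound 3 `CC1=NN(c2ccc(Cl)cc2)C(=O)C12C=CC(=O)C=C2c1ccccc1` likewise gives only a limit in this assay, > 100000 nM. Compound 1 `CC1=NN(c2ccc(C)cc2)C(=O)C12C=CC(=O)C=C2c1ccccc1` gives a number in this assay, 46300 nM. Two of the three values thus sit at the same limit (the limit of > 100000 nM in this assay, at which 2 of the 3 values shown sit). The measured steps are an at least 2.1-fold higher number from compound 1 to compound 2 (0.33 log units; beyond the scatter), an at least 2.1-fold higher number from compound 1 to compound 3 (0.33 log units; beyond the scatter) and a step that the two limits leave unreadable from compound 2 to compound 3; each exchanges one group on an aromatic carbon, and none of them touches the phenyl group. Compound 4 `CC1=NN(c2ccc(Br)cc2)C(=O)C12C=CC(=O)C=C2c1cccc(C)c1` differs from compound 2 by methyl in place of hydrogen on an aromatic carbon. Among the compounds with values here, no measured step carries this change, and nothing in the measured compounds points to a shift in either direction, so the step of a number no higher from compound 2 to compound 4 (the limit leaves the size open) is estimated to leave compound 4 at the limit, with no change beyond the scatter. Compound 4 is therefore expected to give about 100000 nM in this assay, within 40000 nM to 300000 nM.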

Compound 4, half-maximal inhibitory concentration: 45400 nM
The estimate for compound 4 lay 2.2-fold (0.34 log units) above the measured number; low and high end bracket the measured number.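

In this assay, within the data shown here, the change from phenyl to 3-methylphenyl brings an at least 2.2-fold lower number from compound 2 to compound 4 (0.34 log units; beyond the scatter), the first measured step at this group, since the earlier steps exchanged groups only on the other aromatic ring. Compound 4 keeps the bromo of compound 2 and still gives a number, so among the compounds shown a bromo compound is not tied to the limit. How large the step really is stays open because compound 2 gives only a limit of the assay: the limit of > 100000 nM in this assay, at which 2 of the 4 values shown sit.

The compounds shown leave open whether methyl in this place would act in the same way with the chloro of compound 3 or the methyl of compound 1. They also leave open what a methoxy group, a chloro or an amine would do in the same place.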